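Stilbene methoxy series: effect of a second methoxy group

The source may hold more compounds than are shown below. What is called first, only, known or untested is meant among the compounds shown, and "the series" means these compounds.

Measured so far:
- compound 1, `COc1cccc(/C=C/c2ccc(F)cc2)c1`, 6000 nM
- compound 2, `COc1cccc(/C=C/c2cccc(F)c2)c1`, 2300 nM
- compound 3, `COc1ccc(/C=C/c2cccc(F)c2)cc1OC`, 9500 nM

All three compounds were run in an assay on HepG2 cells for activation of nuclear factor erythroid 2-related factor 2 (Homo sapiens), read by a luciferase reporter, with a stated time of 5 h; on this read-out lower numbers stand for an effect already at smaller amounts and higher numbers for an effect only at larger amounts of compound. Compound 2 gives 2300 nM, the lowest number of the three. Compound 1 gives 6000 nM, and compound 3 gives 9500 nM; these two lie within the scatter of each other, so no order between them is read. Compound 1 and compound 2 have the same atoms joined differently; the difference between the two cores is not broken down here.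

One change is seen once among the measured compounds: from compound 2 to compound 3, (methoxy in place of hydrogen on an aromatic carbon). This gave a 4.1-fold higher number from compound 2 to compound 3 (0.62 log units; beyond the scatter).

Compound 4, `COc1ccc(/C=C/c2ccc(F)cc2)cc1OC`, has not yet been measured in this assay. It is related to compound 1 by the same change, (methoxy in place of hydrogen on an aromatic carbon), and the place lines agree word for word, so it is the same change on a core that differs only in where the fluorine stands. Going by the values given here, on that basis, and resting on the single step from compound 2 to compound 3, the step from compound 1 to compound 4 is expected to be of comparable size, about a 4.0-fold higher number from compound 1 to compound 4 (0.60 log units; beyond the scatter). Compound 4 is therefore estimated at 24000 nM, with a range from 10000 nM to 55000 nM, the width reflecting that the expectation rests on one measured pair only.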

Compound 4, half-maximal effective concentration: 2600 nM
Beside the measured number, compound 4's estimate is 9.2-fold (0.97 log units) above it; the measured number lies below the stated range.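

In this assay, methoxy in place of hydrogen on an aromatic carbon gave a 2.3-fold lower number from compound 1 to compound 4 (0.36 log units; beyond the scatter), so the step runs in the opposite direction to the one seen earlier for the same change. For this series, the size and direction of the step do not carry over from one core to the other, even though the two cores differ only in where the fluorine stands: the same change on two cores in this assay, a 4.1-fold higher number (0.62 log units; beyond the scatter) from compound 2 to compound 3 and a 2.3-fold lower number (0.36 log units; beyond the scatter) from compound 1 to compound 4, 9.5-fold (0.98 log units) apart, beyond the scatter of two such steps

This shows that a step measured on one of these cores is a poor guide to the other, but it does not show what lies behind the difference, and with a single pair on each core neither direction can be called the general behaviour of the change.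

The compounds shown carry only fluorine and methoxy groups, so it remains open whether the same dependence on the core appears with chlorine in place of the fluorine. From the compounds shown here alone, it also remains open what a hydroxy group, an amine or a carboxylic acid in place of the added methoxy would give in this assay on each of the two cores.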